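Thioamide Analogue Series on KB Cell Cytotoxicity

This account rests on a few compounds, and the source may have more. Where it says the series, first, only, none or still open, it means among the compounds named here.

Three compounds with a shared core were tested in a functional assay on KB cells (Homo sapiens) for cytotoxicity; a lower number here means a stronger inhibitor, a higher number a weaker inhibitor. Compound 1 `Cc1cccc(Cn2cc(C(N)=O)c3c(N)ncnc32)c1` reaches only a limit of the assay, with a value of > 100000 nM. Compound 2 `CCCn1cc(C(N)=O)c2c(N)ncnc21` gives 100000 nM in this assay. Compound 3 `Cc1cccc(Cn2cc(C(=N)S)c3c(N)ncnc32)c1` gives 30000 nM in this assay, which makes it the lowest number among the two numbers given here.

The step from compound 1 to compound 2 is the change (ethyl in place of 3-methylphenyl on a saturated chain carbon bound to an aromatic nitrogen), and it gives a number no higher from compound 1 to compound 2 (the limit leaves the size open); here the limit of > 100000 nM in this assay, at which 1 of the 3 values shown sits, leaves its size open. The step from compound 1 to compound 3 is the change (a group of 3 heavy atoms (1 carbon, 1 nitrogen, 1 sulfur; no ring) in place of a group of 3 heavy atoms (1 carbon, 1 nitrogen, 1 oxygen; no ring), on an aromatic carbon), and it gives an at least 3.3-fold lower number from compound 1 to compound 3 (0.52 log units; beyond the scatter).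

Compound 4 `CCCn1cc(C(=N)S)c2c(N)ncnc21` has not yet been measured. It differs from compound 3 by ethyl in place of 3-methylphenyl on a saturated chain carbon bound to an aromatic nitrogen, the same change as that from compound 1 to compound 2, made on the same place in the same words. The two cores differ by a group of 3 heavy atoms (1 carbon, 1 nitrogen, 1 sulfur; no ring) in place of a group of 3 heavy atoms (1 carbon, 1 nitrogen, 1 oxygen; no ring), on an aromatic carbon.

Since the earlier step of this kind gave a number no higher from compound 1 to compound 2 (the limit leaves the size open) with its size left open, compound 4 is expected to sit near compound 3 or somewhat higher, an estimated step of a 1.7-fold higher number from compound 3 to compound 4 (0.22 log units; within the scatter). Compound 4 is therefore estimated at 50000 nM in this assay, with a range expected from 15000 nM to 150000 nM.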

Compound 4, half-maximal inhibitory concentration: 17000 nM
The estimate for compound 4 lay 2.9-fold (0.47 log units) above the measured number, within the range that was stated.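

On the core of compound 3, ethyl in place of 3-methylphenyl gives in this assay a 1.8-fold lower number from compound 3 to compound 4 (0.25 log units; within the scatter), so the change shows no clear effect on this core, and the comparison with the core of compound 1 stays unsettled: the same change on two cores in this assay, a number no higher (the limit leaves the size open) from compound 1 to compound 2 and a 1.8-fold lower number (0.25 log units; within the scatter) from compound 3 to compound 4; the limit leaves it open whether they differ The replacement on the aromatic carbon gives a 5.9-fold lower number from compound 2 to compound 4 (0.77 log units; beyond the scatter), and on both cores that replacement goes with a lower number, which is the one trend that holds across all the pairs shown here: the same change on two cores in this assay, an at least 3.3-fold lower number (0.52 log units; beyond the scatter) from compound 1 to compound 3 and a 5.9-fold lower number (0.77 log units; beyond the scatter) from compound 2 to compound 4; the limit leaves it open whether they differ Compound 1 carries a limit, so the steps that start from it cannot be read for size, and these compounds do not show that either change has the same size on both cores.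

The compounds shown leave open whether a longer chain, such as butyl, or a benzyl group without the methyl would give numbers like those of compound 3 and compound 4 on this core. They also leave open whether a nitrile or a carboxylic acid on the same aromatic carbon would go with a lower number, as the group in compound 3 and compound 4 does.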